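The compounds below may be only part of what the source reports. "The series", "measured", "known", "first", "only" and "open" are said of these compounds alone.

Compound 1: `COc1cc(NC(C)CCCNC(=O)NNC(=O)Nc2ccc(Cl)cc2)c2ncccc2c1`, 180 nM in a functional assay on MCF7 cells (Homo sapiens) for inhibition, read by MTT assay, with a stated time of 72 h; a higher number here means a weaker inhibitor, a lower number a stronger inhibitor.
Compound 2: `COc1cc(NC(C)CCCNC(=O)Nc2cc(C(F)(F)F)cc(C(F)(F)F)c2)c2ncccc2c1`, 1600 nM in this assay.

Compound 1 has the lowest value of these two; compound 2 is clearly weaker, and the gap between them lies beyond the usual scatter. Compound 3 is `COc1cc(NC(C)CCCNC(=O)Nc2ccc(O)cc2)c2ncccc2c1`, which differs from compound 1 in one place: 4-hydroxyphenyl in place of ((4-chlorophenyl)carbamoyl)amino on an amide-type nitrogen. Because compound 2, whose aromatic ring also sits directly on that nitrogen, gives 1600 nM, a step toward weaker inhibition beyond the scatter is expected, a 4.4-fold higher number from compound 1 to compound 3 (0.65 log units; beyond the scatter). The estimate for compound 3 in this assay is 800 nM, ranging from 250 nM to 3000 nM.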

Compound 3, half-maximal inhibitory concentration: 5200 nM
Compound 3: the middle estimate sits 6.5-fold (0.81 log units) below what was measured; measured number outside the range, above it.
By their numbers in this assay, from the lowest: compound 1; then compound 2; then compound 3.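

In this assay, putting 4-hydroxyphenyl in place of ((4-chlorophenyl)carbamoyl)amino on the amide-type nitrogen gives a 29-fold higher number from compound 1 to compound 3 (1.46 log units; beyond the scatter), so what this position carries matters greatly. The change swaps 11 heavy atoms for 7 and also removes the chlorine, so this single step cannot show which part counts. Nothing available here explains the loss. Still open, going by these compounds, is whether keeping the ((4-chlorophenyl)carbamoyl)amino link but changing its chlorine would matter as much. Also open, on these data alone, is how a phenyl ring carrying an amine or a carboxylic acid instead of the hydroxyl would compare.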